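The source may report more compounds than this note shows. Statements on the series, on what has been measured and on what is new or still open speak of the compounds shown alone.

Measured in an ADME assay on HEK293 cells (Homo sapiens) for cytotoxicity, read by MTT assay, with a stated time of 48 h; a higher number here means a weaker inhibitor, a lower number a stronger inhibitor:
compound 1 `O=C1/C(=C\c2ccc(O)cc2)S/C(=N/c2ccccc2)N1Cc1ccncc1`: 142000 nM
compound 2 `O=C1/C(=C\c2ccc([N+](=O)[O-])cc2)S/C(=N/c2ccccc2)N1Cc1ccncc1`: 250000 nM

Compound 2 stands level with compound 1 within the scatter (a 1.8-fold higher number from compound 1 to compound 2 (0.25 log units; within the scatter)). Compound 3 `CN(C)c1ccc(/C=C2/S/C(=N/c3ccccc3)N(Cc3ccncc3)C2=O)cc1` has dimethylamino in place of nitro on an aromatic carbon para to a large group. Within the data shown here, only one measured step bears on this change, nitro in place of hydroxy on an aromatic carbon (a 1.8-fold higher number from compound 1 to compound 2 (0.25 log units; within the scatter)). That step stayed within the scatter, so no step beyond the scatter is expected in this assay. The expected step is small (a 1.5-fold lower number from compound 2 to compound 3 (0.17 log units; within the scatter)). For compound 3 the estimate is 170000 nM (expected range 70000 nM to 350000 nM).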

Compound 3, half-maximal inhibitory concentration: 122000 nM
For compound 3 the middle estimate is 1.4-fold (0.14 log units) above the measured one; the range from low to high includes it.
By their numbers in this assay, from the lowest: compounds 3, 1 and 2 (each within the scatter of the next, the first and the last beyond it).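

In this assay, among these compounds, dimethylamino in place of nitro at this position, on an aromatic carbon para to a large group, gives the first step beyond the scatter, though a modest one (a 2.0-fold lower number from compound 2 to compound 3 (0.31 log units; beyond the scatter)). Dimethylamino in place of hydroxy stays within the scatter (a 1.2-fold lower number from compound 1 to compound 3 (0.07 log units; within the scatter)), so only the nitro and dimethylamino pair separates. Nothing available accounts for this step. Going by these compounds, how a carboxylic acid or a fluorine at this position would compare remains open. So does whether changes elsewhere on the shared core would move the number further.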